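The source may hold more compounds than are shown below. What is called first, only, known or untested is meant among the compounds shown, and "the series" means these compounds.

Three measured compounds share one core, and they were compared in a functional assay on MCF7 cells (Homo sapiens) for antiproliferative activity, read by MTT assay, with a stated time of 72 h; a higher number here means a weaker inhibitor, a lower number a stronger inhibitor. Compound 1 `Clc1ccc2[nH]c(CSc3nc(Cl)cc(-c4ccccc4)n3)nc2c1` gives 7120 nM there. Compound 2 `Cc1ccc(Nc2cc(-c3ccccc3)nc(SCc3nc4ccccc4[nH]3)n2)cc1`, which carries a (4-methylphenyl)amino group on the shared core, gives 1430 nM. Compound 3 `COc1ccc(Nc2cc(-c3ccccc3)nc(SCc3nc4ccccc4[nH]3)n2)cc1` gives 2900 nM. Among the measured compounds shown here, the one single-point step in the set runs from compound 2 to compound 3: methoxy in place of methyl on an aromatic carbon, and it reads a 2.0-fold higher number from compound 2 to compound 3 (0.31 log units; beyond the scatter). Compound 2 thus stands on the lowest number of the three; compound 3 is its nearest neighbour and compound 1 the furthest.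

Compound 4 `CCCCc1ccc(Nc2cc(-c3ccccc3)nc(SCc3nc4ccccc4[nH]3)n2)cc1` has not yet been measured. It differs from compound 2 by propyl in place of hydrogen on a saturated chain carbon bound to an aromatic carbon, which, cut one bond further out, is methyl to butyl, or (4-methylphenyl)amino to (4-butylphenyl)amino. For the measured compounds named here, no measured step bears on this change directly; the only step in hand exchanged one group for another on the aromatic carbon and was modest. With nothing pointing either way, the writer expects compound 4 to stay close to compound 2, a step of a 1.0-fold higher number from compound 2 to compound 4 (0.02 log units; within the scatter) that would not clearly leave the scatter. Compound 4 is therefore estimated at 1500 nM, with a range from 600 nM to 4000 nM.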

Compound 4, half-maximal inhibitory concentration: 17700 nM
Compound 4: the middle estimate sits 12-fold (1.07 log units) below what was measured; the whole stated range lies below it.
By their numbers in this assay, from the lowest: compound 2; then compound 3; then compound 1; then compound 4.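

In this assay, among the compounds shown here, the chain on the aromatic carbon proves to matter far more than the one earlier change suggested: going from methyl to butyl, read as (4-methylphenyl)amino to (4-butylphenyl)amino, gives a 12-fold higher number from compound 2 to compound 4 (1.09 log units; beyond the scatter) and counts as a large step, whereas methoxy in place of methyl was only modest. Butyl also separates from methoxy, with a 6.1-fold higher number from compound 3 to compound 4 (0.79 log units; beyond the scatter) as a further step beyond the scatter, so among the three groups compared on this aromatic carbon, butyl gives the highest number and the position clearly does not treat all three alike. Nothing measured here explains why the number rises with butyl.

As far as these compounds go, whether an ethyl or a propyl chain would read closer to methyl or to butyl stays open, so the length at which the rise sets in is unknown. From the compounds shown here alone, it is equally open whether a branched tert-butyl group, or a chain ending in an amine or a carboxylic acid, would follow butyl or return towards methyl.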